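Swapping the amino group for a methyl on compound 3's ring

A few compounds are considered here, and "the series" means these few. Any claim that something is new, unique, unknown or untested is made for them only; others in the source may bear on it.

Compound 3 `Nc1cccc(CCCCCC(=O)N2CCOC2=O)c1` was tested in an assay on HEK293 cells for inhibition of N-acylethanolamine-hydrolyzing acid amidase (Rattus norvegicus), read by LC-MS, with a stated time of 30 min (on this read-out higher numbers stand for weaker inhibition and lower numbers for stronger inhibition), which reads out a half-maximal inhibitory concentration. For compound 3 the result is a limit of the assay, > 20000 nM, and not a measured number. Two of the three values shown sit at this limit (the limit of > 20000 nM in this assay, at which 2 of the 3 values shown sit). Compound 1 `O=C(CCCCCc1cccc(O)c1)N1CCOC1=O` carries a hydroxy group on the same ring and gives 8640 nM in this assay. Compound 2 `NC(=O)c1cccc(CCCCCC(=O)N2CCOC2=O)c1` carries a carbamoyl group there instead; its result is also a limit, > 20000 nM.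

Compound 4 `Cc1cccc(CCCCCC(=O)N2CCOC2=O)c1` differs from compound 3 by methyl in place of amino on an aromatic carbon. Among the measured compounds shown here, no measured step involves a methyl, so the nearest guidance comes from the steps that remove the hydroxy of compound 1: an at least 2.3-fold higher number from compound 1 to compound 2 (0.36 log units; beyond the scatter) and an at least 2.3-fold higher number from compound 1 to compound 3 (0.36 log units; beyond the scatter). The step between the two limits, a step that the two limits leave unreadable from compound 2 to compound 3, gives no usable size. Both known replacements of the hydroxy weakened inhibition at least modestly, and a methyl offers neither a hydrogen-bond donor nor an acceptor, so no recovery is expected; the most likely outcome is that compound 4 also reaches the limit. Compound 4 is therefore expected to give about 25000 nM, within a range from 8000 nM to 80000 nM, which as an expected step means a step that the limit leaves unreadable from compound 3 to compound 4.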

Compound 4, half-maximal inhibitory concentration: 350 nM
Beside the measured number, compound 4's estimate is 71-fold (1.85 log units) above it; the whole stated range lies above it.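

In this assay, methyl in place of amino on an aromatic carbon gives an at least 57-fold lower number from compound 3 to compound 4 (1.75 log units; beyond the scatter), and methyl in place of carbamoyl gives an at least 57-fold lower number from compound 2 to compound 4 (1.75 log units; beyond the scatter). Among the compounds shown here, compound 1 had been the only compound of the earlier three with a measured number, which left open whether its hydroxy was needed, but methyl, with 0 hydrogen-bond donors and 0 hydrogen-bond acceptors, gives a 25-fold lower number from compound 1 to compound 4 (1.39 log units; beyond the scatter), so strong inhibition at this place meta to a large group requires neither a donor nor an acceptor, and compound 4 is the strongest of the four. Compound 2 and compound 3 each give a limit of the assay and not a number, and the step between them cannot be read: the limit of > 20000 nM in this assay, at which 2 of the 4 values shown sit.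

One methyl cannot show whether the gain belongs to that group specifically or would extend to other groups without a donor or acceptor, such as an ethyl, a chlorine or a trifluoromethyl. The compounds shown also leave open how a methoxy, which adds an oxygen to the methyl, or a methyl at another place on the ring, would compare with compound 4.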